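A few compounds are considered here, and "the series" means these few. Any claim that something is new, unique, unknown or untested is made for them only; others in the source may bear on it.

Measured so far:
- compound 1 `O=C(Nc1nccs1)c1cccc(Nc2ncc(F)c(Nc3ccc(F)cc3)n2)c1`: > 10000 nM (a limit of the assay, not a number)
- compound 2 `O=C(Nc1cccc(Nc2ncc(F)c(Nc3ccc(F)cc3)n2)c1)c1cccc([N+](=O)[O-])c1`: 12600 nM

Among the measured compounds shown here, in a functional assay on DU-145 cells (Homo sapiens) for antiproliferative activity, read by sulforhodamine B assay, with a stated time of 3 days (on this read-out higher numbers stand for weaker inhibition of growth and lower numbers for stronger inhibition of growth), compound 2 gives 12600 nM, the only actual number so far. Compound 3 `O=C(Nc1cccc(Nc2ncc(F)c(Nc3ccc(F)cc3)n2)c1)c1ccccc1` has hydrogen in place of nitro on an aromatic carbon, the 3-nitrophenyl becoming phenyl: hydrogen in place of nitro on an aromatic carbon. For the measured compounds named here, no measured step covers this change. With compound 2 at 12600 nM as the sole reference, no shift beyond the scatter is expected in this assay. The expected 1.1-fold lower number from compound 2 to compound 3 (0.02 log units; within the scatter) is therefore small. For compound 3 the estimated value is 12000 nM, expected to fall between 5000 nM and 30000 nM.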

Compound 3, concentration for 50% growth inhibition: > 10000 nM
Compound 3 ended at the assay's limit; the forecaster's own chance of this, stated with the estimate: 40%; the middle value is on the limit's open side.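

No step can be read from compound 2 to compound 3 or from compound 1 to compound 3, because compound 1 and compound 3 are recorded only as a limit: the limit of > 10000 nM in this assay, at which 2 of the 3 values shown sit.

Open: how far compound 1 and compound 3 actually lie from compound 2, and whether removing nitro changes growth inhibition at all.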